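The source may report more compounds than this note shows. Statements on the series, on what has been measured and on what is new or still open speak of the compounds shown alone.

In a functional assay on U-937 cells (Homo sapiens) for cytotoxicity, read by MTT assay, with a stated time of 3 days (a higher number here means a weaker inhibitor, a lower number a stronger inhibitor), compound 1 (`N#Cc1c(Nc2ccccc2)nc(SCc2nc3ccccc3[nH]2)nc1-c1ccccc1`) gives 3.28 nM, compound 2 (`N#Cc1c(Nc2ccccn2)nc(SCc2nc3ccccc3[nH]2)nc1-c1ccccc1`) gives 2.55 nM and compound 3 (`N#Cc1c(NNC(N)=S)nc(SCc2nc3ccccc3[nH]2)nc1-c1ccccc1`) gives 3 nM, so compound 1 lies within the scatter of both others. Compound 4 (`N#Cc1c(-c2ccccc2)nc(SCc2nc3ccccc3[nH]2)nc1N1CCNCC1`) carries piperazin-1-yl in place of anilino on an aromatic carbon. Two measured changes to the anilino group bear on this: a 1.3-fold lower number from compound 1 to compound 2 (0.11 log units; within the scatter) with pyridin-2-yl in place of phenyl, and a 1.1-fold lower number from compound 1 to compound 3 (0.04 log units; within the scatter) with a group that has no ring. Both are within the scatter. Within the data shown here, no measured compound has a non-aromatic ring there, so the range stays wide. No step beyond the scatter is expected in this assay, the expected change being a 1.1-fold lower number from compound 1 to compound 4 (0.04 log units; within the scatter). Compound 4 is estimated at 3 nM, with an expected range of 1.3 nM to 7.5 nM.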

Compound 4, half-maximal inhibitory concentration: 5.81 nM
Compound 4: middle estimate off by 1.9-fold (0.29 log units), on the low side, and the stated range covers the measured number.
By their numbers in this assay, from the lowest: compounds 2, 3, 1 and 4 (each within the scatter of the next, the first and the last beyond it).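

Among these compounds, on the aromatic carbon that carries these groups, piperazin-1-yl brings a non-aromatic ring into the series, and in this assay it gives the first step beyond the scatter, though a modest one: a 2.3-fold higher number from compound 2 to compound 4 (0.36 log units; beyond the scatter). The other two steps, a 1.8-fold higher number from compound 1 to compound 4 (0.25 log units; within the scatter) and a 1.9-fold higher number from compound 3 to compound 4 (0.29 log units; within the scatter), stay within the scatter, so the non-aromatic ring is set apart only from the (pyridin-2-yl)amino group. Nothing measured here accounts for that step.

Whether the second ring nitrogen of piperazin-1-yl matters remains open, since morpholin-4-yl is not among the compounds shown. An open-chain amine such as 2-aminoethylamino at this position is also untested in these data.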